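A few compounds are considered here, and "the series" means these few. Any claim that something is new, unique, unknown or untested is made for them only; others in the source may bear on it.

Measured compounds:
compound 1, `O=C(O)CCC(=O)N1N=C(c2c(-c3ccccc3)c3cc(Cl)ccc3[nH]c2=O)CC1c1ccc(Br)cc1`, 3100 nM in an assay on cells (Oocyte) for negative allosteric modulation of glutamate receptor ionotropic, NMDA 2D (Rattus norvegicus), read by two-electrode voltage clamp; on this read-out higher numbers stand for weaker inhibition and lower numbers for stronger inhibition;
compound 2, `O=C(O)CCC(=O)N1N=C(c2c(-c3ccccc3)c3cc(Cl)ccc3[nH]c2=O)CC1c1ccc([N+](=O)[O-])cc1`, 1100 nM;
compound 3, `Cc1cccc(-c2c(C3=NN(C(=O)CCC(=O)O)C(c4ccc(Cl)cc4)C3)c(=O)[nH]c3ccccc23)c1`, 1900 nM.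

Compound 3 stands second highest of the three numbers. Its value sits within the scatter of both neighbours: compound 1 lies a little higher and compound 2 a little lower, so no order among these three can be read from the numbers. Within the data shown here, the only change measured in one place is a 2.8-fold lower number from compound 1 to compound 2 (0.45 log units; beyond the scatter), a modest step beyond the scatter.

Compound 4, `O=C(O)CCC(=O)N1N=C(c2c(-c3cc(Cl)cc(Cl)c3)c3ccccc3[nH]c2=O)CC1c1ccc(Cl)cc1`, is not yet measured. It differs from compound 3 by 3,5-dichlorophenyl in place of 3-methylphenyl on an aromatic carbon. Among the measured compounds shown here, no measured step touches this position: the one step seen, from compound 1 to compound 2, concerns the aryl group on the saturated ring, not the group on the fused core. Compound 1 and compound 3 differ in several places at once, so they give no clean guide either. With nothing pointing in either direction, the expected step is a 1.2-fold lower number from compound 3 to compound 4 (0.07 log units; within the scatter), not beyond the scatter. Compound 4 is therefore estimated at 1600 nM, in the range 500 nM to 5000 nM.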

Compound 4, half-maximal inhibitory concentration: 700 nM
Compound 4: the middle estimate sits 2.3-fold (0.36 log units) above what was measured; the measured number falls inside the stated range.
By their numbers in this assay, from the lowest: compounds 4, 2, 3 and 1 (each within the scatter of the next, the first and the last beyond it).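

Exchanging 3-methylphenyl for 3,5-dichlorophenyl on the aromatic carbon opposite the ring nitrogen gives a 2.7-fold lower number from compound 3 to compound 4 (0.43 log units; beyond the scatter) in this assay, which means stronger inhibition. Among these compounds, this is the first clean evidence that the aryl group at this position can influence the read-out, as the earlier step between compound 1 and compound 2 concerned a different aryl group. Nothing measured here explains why this change strengthens inhibition.

Because the change removes a methyl group and adds two chlorine atoms at once, the compounds shown leave open whether 3-chlorophenyl alone would produce a similar step. Going by these compounds, how a methoxy group, an amine or a nitrile on this phenyl ring would compare also remains open.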